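Swapping a Benzyl Arm for a Phenoxy Arm

A few compounds are considered here, and "the series" means these few. Any claim that something is new, unique, unknown or untested is made for them only; others in the source may bear on it.

Compound 2 `COc1ccc(F)cc1CNCCCNc1ccnc2cc(Cc3ccc(F)cc3)ccc12` gives 3530 nM in an ADME assay on HepG2 cells (Homo sapiens) for cytotoxicity, read by luminescence, CellTiter-Glo and ATP content, with a stated time of 72 h (on this read-out higher numbers stand for an effect only at larger amounts of compound and lower numbers for an effect already at smaller amounts), the lower of two numbers. Compound 1 `COc1ccc(F)cc1CNCCCNc1ccnc2cc(Cc3ccc(C#N)cc3)ccc12` gives 6050 nM in this assay, and the step of a 1.7-fold lower number from compound 1 to compound 2 (0.23 log units; within the scatter) is small. Compound 3 `COc1ccc(F)cc1CNCCCNc1ccnc2cc(Oc3ccccc3OC)ccc12` differs from compound 2 by 2-methoxyphenoxy in place of 4-fluorobenzyl on an aromatic carbon. Going by the values given here, no measured step concerns this kind of change, since the only known step exchanges one small substituent on that outer ring, so the expectation rests on compound 2 alone: a step of a 1.3-fold higher number from compound 2 to compound 3 (0.11 log units; within the scatter) is expected, with no direction beyond the scatter. Compound 3 is therefore estimated at 4500 nM in this assay, within 1500 nM to 14000 nM.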

Compound 3, half-maximal effective concentration: 6400 nM
The estimate for compound 3 lay 1.4-fold (0.15 log units) below the measured number; low and high end bracket the measured number.
By their numbers in this assay, from the lowest: compounds 2, 1 and 3 (each within the scatter of the next).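

Replacing the whole benzyl arm with 2-methoxyphenoxy, rather than only a small substituent on its outer ring, gives a 1.8-fold higher number from compound 2 to compound 3 (0.26 log units; within the scatter) and a 1.1-fold higher number from compound 1 to compound 3 (0.02 log units; within the scatter) in this assay and so leaves the number within the scatter. At this position, even an arm that brings hydrogen-bond acceptors the benzyl arms lack does not separate the three compounds. No measurement at hand offers a reason for this. Still open, on these data alone, is whether an amine or a carboxylic acid on this carbon would move the number beyond the scatter, and whether plain phenoxy would match 2-methoxyphenoxy.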